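Shortening the chain and swapping the azole on a phenol core

The source may hold more compounds than are shown below. What is called first, only, known or untested is meant among the compounds shown, and "the series" means these compounds.

Measured compounds:
compound 1, `CCc1cc(C(C)=O)c(O)cc1OCCCCCC(C)(C)C#N`, 53%
compound 2, `CCc1cc(C(C)=O)c(O)cc1OCCCC(C)(C)C(N)=O`, 51%
compound 3, `CCc1cc(C(C)=O)c(O)cc1OCCCCCC(C)(C)c1nnn(C)n1`, 66%

In an assay on isolated protein for binding affinity to leukotriene B4 receptor 1 (Homo sapiens), tested at 1 uM (a lower number here means less inhibition, a higher number more inhibition at the concentration tested (going by the name of the read-out)), compound 3 gives 66%, the highest of the three numbers; the nearest is compound 1 and the furthest compound 2, both beyond the scatter. Compound 4, `CCc1cc(C(C)=O)c(O)cc1OCCCCCn1cncn1`, has not been measured. Its difference from compound 3 is 1H-1,2,4-triazol-1-yl in place of 1-methyl-1-(2-methyl-2H-tetrazol-5-yl)ethyl on a saturated chain carbon, five bonds along the chain from an oxygen on an aromatic ring.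

Two measured steps exist. The change a number 2 percentage points lower from compound 1 to compound 2 (within the scatter), trading the nitrile end for a carbamoyl end on a shorter chain, left the number where it was. The change a number 13 percentage points higher from compound 1 to compound 3 (beyond the scatter), a tetrazole in place of a nitrile on the same carbon, raised it modestly. Neither step removes the branching carbon or shortens the chain while moving an azole onto it, as happens from compound 3 to compound 4, so the direction rests on weak footing. Since the gain of compound 3 came with the tetrazole in a number 13 percentage points higher from compound 1 to compound 3 (beyond the scatter), losing that group is expected to cost part of it; an estimate of a number 16 percentage points lower from compound 3 to compound 4 (beyond the scatter) follows. Compound 4 is therefore expected to give 50%, within 30% to 68%.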

Compound 4, a percentage reported as inhibition, at one concentration (the size of the read-out at that concentration, not a potency): 30%
Beside the measured number, compound 4's estimate is 20 percentage points above it, and the stated range covers the measured number.
By their numbers in this assay, from the lowest: compound 4; then compounds 2 and 1 (each within the scatter of the next); then compound 3.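

In this assay the move to 1H-1,2,4-triazol-1-yl on this saturated chain carbon is a number 36 percentage points lower from compound 3 to compound 4 (beyond the scatter) and counts as a large fall, so what the chain carries at this place matters to the number. The fall is not tied to the tetrazole alone: the nitrile end gives a number 23 percentage points lower from compound 1 to compound 4 (beyond the scatter) and the carbamoyl end gives a number 21 percentage points lower from compound 2 to compound 4 (beyond the scatter) as well, so all three earlier chain ends stand above the triazole. No evidence on why the number fell comes with these compounds.

The compounds shown leave open whether the fall follows the triazole ring itself or the loss of the branching carbon with its two methyl groups. On these data alone, what a carboxylic acid, an amine or a 1H-imidazol-1-yl at the same place would give also remains open.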